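Trimethoxyphenyl triazole thioethers: ketone to amide switch

This account rests on a few compounds, and the source may have more. Where it says the series, first, only, none or still open, it means among the compounds named here.

Measured so far:
compound 1 `COc1cc(-c2nnc(SCC(=O)c3ccc(C(F)(F)F)cc3)n2N)cc(OC)c1OC` > 100000 nM
compound 2 `COc1cc(-c2nnc(SCC(=O)c3cccc(Br)c3)n2N)cc(OC)c1OC` > 100000 nM

Compound 1 has the structure `COc1cc(-c2nnc(SCC(=O)c3ccc(C(F)(F)F)cc3)n2N)cc(OC)c1OC`. In a functional assay on PC-3 cells (Homo sapiens) for antiproliferative activity, read by MTT assay, with a stated time of 48 h (on this read-out higher numbers stand for weaker inhibition and lower numbers for stronger inhibition), compound 1 returns only a limit, > 100000 nM. Compound 2, `COc1cc(-c2nnc(SCC(=O)c3cccc(Br)c3)n2N)cc(OC)c1OC`, likewise returns only a limit in this assay, > 100000 nM. Among the measured compounds shown here, the one step between measured compounds, a step that the two limits leave unreadable from compound 1 to compound 2, therefore cannot be sized; both values sit at the limit of > 100000 nM in this assay, at which 2 of the 2 values shown sit.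

Compound 3 is `COc1cc(-c2nnc(SCC(=O)NCc3ccc(C)cc3)n2N)cc(OC)c1OC`. It differs from compound 1 by (4-methylbenzyl)amino in place of 4-(trifluoromethyl)phenyl on a carbonyl carbon. For the measured compounds named here, no measured step bears directly on this change; the only comparison available is the pair at the limit. The expectation for compound 3 is therefore that it remains at or near the limit, with an estimated step of a number no higher from compound 1 to compound 3 (the limit leaves the size open). Compound 3 is estimated at 100000 nM, within 30000 nM to 300000 nM.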

Compound 3, half-maximal inhibitory concentration: 92800 nM
The estimate for compound 3 lay 1.1-fold (0.03 log units) above the measured number, and the stated range covers the measured number.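

In this assay, placing (4-methylbenzyl)amino on the carbonyl carbon turns the ketone into an amide and gives the only actual number among the compounds shown, where the two ketones return only limits: the limit of > 100000 nM in this assay, at which 2 of the 3 values shown sit.

The readable steps are an at least 1.0-fold lower number from compound 1 to compound 3 (0.03 log units; that floor lies within the scatter) and an at least 1.0-fold lower number from compound 2 to compound 3 (0.03 log units; that floor lies within the scatter). Both rest on limits, so they are floors only: they show that this position accepts the amide without the read-out leaving the measurable range, but they establish no real gain over either ketone.

Compound 3 brings in the amide hydrogen, the benzyl carbon and the 4-methyl group in a single change, and their contributions cannot be separated here. From the compounds shown here alone, whether a carboxylic acid, a cyclic amine or a longer chain on this carbonyl carbon would shift the number remains open.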